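Swapping 4-chlorophenyl for 3-methoxyphenyl in compound 3

The compounds below may be only part of what the source reports. "The series", "measured", "known", "first", "only" and "open" are said of these compounds alone.

Values so far in an ADME assay on NHDF cells (Homo sapiens) for cytotoxicity, read by MTT assay, with a stated time of 72 h (a higher number here means a weaker inhibitor, a lower number a stronger inhibitor), for three compounds
Compound 1 `COc1cccc(/C=C2\CCC/C(=C\c3ccc(O)cc3)C2=O)c1OC` gives > 50000 nM (a limit)
Compound 2 `COc1cccc(/C=C2\CCC/C(=C\c3cc(OC)c(OC)c(OC)c3)C2=O)c1OC` gives 7900 nM
Compound 3 `COc1ccc(/C=C2\CCC/C(=C\c3ccc(Cl)cc3)C2=O)cc1OC` gives 11200 nM

Compound 1 has only > 50000 nM as its entry, and this is a limit of the assay and not a number. That leaves two true numbers to compare. Compound 3 at 11200 nM and compound 2 at 7900 nM lie within the usual scatter of each other, so this assay does not separate them.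

The next molecule is compound 4 `COc1cccc(/C=C2\CCC/C(=C\c3ccc(OC)c(OC)c3)C2=O)c1` and it has not been measured yet. It carries 3-methoxyphenyl in place of 4-chlorophenyl on a double-bonded chain carbon bound to a double-bonded ring carbon and the rest of compound 3 stays as it is.

For the measured compounds named here, no measured pair here shows a single change of this kind, so there is no direct guide to its size. The best available anchor is compound 3 at 11200 nM in this assay, and no step beyond the scatter is expected in this assay for this swap. The estimated step of a 1.1-fold higher number from compound 3 to compound 4 (0.03 log units; within the scatter) is therefore small. For compound 4 the expected value is 12000 nM with an estimated range of 4500 nM to 32000 nM once it is tested.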

Compound 4, half-maximal inhibitory concentration: 11600 nM
Estimate against measurement, compound 4: 1.0-fold (0.01 log units) above; the measured number falls inside the stated range.
By their numbers in this assay, from the lowest: compounds 2, 3 and 4 (each within the scatter of the next). At a limit, above all of these: compound 1.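

On a double-bonded chain carbon bound to a double-bonded ring carbon, 3-methoxyphenyl in place of 4-chlorophenyl gives, in this assay, a 1.0-fold higher number from compound 3 to compound 4 (0.02 log units; within the scatter). For the compounds shown here, this is the first change in one single place that can be read in this set, and it shows that this position takes a ring carrying a methoxy group instead of one carrying chlorine, and so gains a hydrogen-bond acceptor, with no difference this cell assay can separate. The one line of supporting data concerns only the assay limit and says nothing about why this swap leaves the number where it is.

From the compounds shown here alone, whether the same holds for quite different groups at this place, such as an amine, a carboxylic acid or a longer chain in place of the aromatic ring, stays open, since both groups compared here are substituted phenyl rings. Going by these compounds alone, compound 1 gives > 50000 nM, which is a limit of the assay, so no step to it can be read, and what a hydroxyl-bearing ring does at this place remains unsettled.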